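The source may report more compounds than this note shows. Statements on the series, on what has been measured and on what is new or still open speak of the compounds shown alone.

Values in a functional assay on HepG2 cells (Homo sapiens) for antiproliferative activity, read by sulforhodamine B assay, with a stated time of 72 h; on this read-out higher numbers stand for weaker inhibition and lower numbers for stronger inhibition:
- Compound 1 `O=C(Cn1nc(-c2ccccc2)c2ccccc2c1=O)Nc1ccccc1`: 13400 nM
- Compound 2 `COc1ccc(NC(=O)Cn2nc(-c3ccccc3)c3ccccc3c2=O)cc1`: > 100000000 nM (a limit of the assay, not a number)
- Compound 3 `O=C(Cn1nc(-c2ccccc2)c2ccccc2c1=O)Nc1ccc(Cl)cc1`: 10300 nM

For the measured compounds named here, compound 3 stands level with the only other true number in the set: chloro in place of hydrogen on an aromatic carbon gives a 1.3-fold lower number from compound 1 to compound 3 (0.11 log units; within the scatter). Methoxy in place of hydrogen on an aromatic carbon gives an at least 7400-fold higher number from compound 1 to compound 2 (3.87 log units; beyond the scatter), and that step ends at a limit. One change can therefore leave the number in place or move it greatly.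

Compound 4 `O=C(Cn1nc(-c2ccccc2)c2ccccc2c1=O)Nc1cccc(C(F)(F)F)c1`, not yet measured, carries 3-(trifluoromethyl)phenyl in place of 4-chlorophenyl on an amide-type nitrogen. Neither measured step is this exact swap. The chloro step, a 1.3-fold lower number from compound 1 to compound 3 (0.11 log units; within the scatter), serves as the main guide, and the methoxy step, an at least 7400-fold higher number from compound 1 to compound 2 (3.87 log units; beyond the scatter), as a warning that a large jump remains possible. The expected result is no step beyond the scatter, estimated as a 1.1-fold lower number from compound 3 to compound 4 (0.06 log units; within the scatter). For compound 4 the estimated value is 9000 nM, with an expected range from 3000 nM to 40000 nM.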

Compound 4, half-maximal inhibitory concentration: 3500 nM
For compound 4 the middle estimate is 2.6-fold (0.41 log units) above the measured one; the range from low to high includes it.
By their numbers in this assay, from the lowest: compound 4; then compounds 3 and 1 (each within the scatter of the next). At a limit, above all of these: compound 2.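

In this assay, trifluoromethyl in place of hydrogen gives a 3.8-fold lower number from compound 1 to compound 4 (0.58 log units; beyond the scatter), the first change from compound 1 shown here that lowers the number beyond the scatter. Replacing 4-chlorophenyl with 3-(trifluoromethyl)phenyl on the amide-type nitrogen gives a 2.9-fold lower number from compound 3 to compound 4 (0.47 log units; beyond the scatter), so a change at this site can give a modest step as well as leave the number in place or move it greatly. The remaining step, an at least 28000-fold lower number from compound 2 to compound 4 (4.45 log units; beyond the scatter), starts from a limit and not a number: the limit of > 100000000 nM in this assay, at which 1 of the 4 values shown sits.

On these data alone, whether the lower number follows the trifluoromethyl group itself or its place on the ring stays open. Also open, as far as these compounds go, is what other groups on this ring, such as an amine or a carboxylic acid, would do.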